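A few compounds are considered here, and "the series" means these few. Any claim that something is new, unique, unknown or untested is made for them only; others in the source may bear on it.

Three compounds share one core and carry either a chloro or a methoxy group on its carbon-only aromatic ring. Compound 1 `CCc1cccc(CNC(=O)c2nc3ccc(Cl)c(COCc4ccc(C(=O)O)cc4)c3c(=O)[nH]2)c1`, compound 2 `CCc1cccc(CNC(=O)c2nc3ccc(OC)c(COCc4ccc(C(=O)O)cc4)c3c(=O)[nH]2)c1` and compound 3 `CCc1cccc(CNC(=O)c2nc3c(Cl)ccc(COCc4ccc(C(=O)O)cc4)c3c(=O)[nH]2)c1` were tested in an ADME assay on HEK293 cells (Homo sapiens) for cytotoxicity, read by resazurin assay, with a stated time of 72 h; a higher number here means that more compound is tolerated, a lower number that less compound is tolerated. In this assay compound 1 gives > 20000 nM, which is a limit of the assay and not a number. Compound 2 gives > 20000 nM, also a limit. Compound 3 gives > 20000 nM, again a limit. The change methoxy in place of chloro on an aromatic carbon therefore gives a step that the two limits leave unreadable from compound 1 to compound 2 because of the limit of > 20000 nM in this assay, at which 3 of the 3 values shown sit. The difference between the core of compound 1 and the core of compound 3 is not broken down here. Compound 4 `CCc1cccc(CNC(=O)c2nc3c(OC)ccc(COCc4ccc(C(=O)O)cc4)c3c(=O)[nH]2)c1` has not been measured; it differs from compound 3 by methoxy in place of chloro on an aromatic carbon. This is the same kind of change as from compound 1 to compound 2, not the same: in the first it sits ortho to a ((4-carboxybenzyl)oxy)methyl group, meta to a fused ring and para to a fused ring, while here it sits ortho to a fused ring, meta to a fused ring and para to a ((4-carboxybenzyl)oxy)methyl group. Going by the values given here, with a step that the two limits leave unreadable from compound 1 to compound 2 as the only guide, the step from compound 3 to compound 4 is expected to be a step that the limit leaves unreadable from compound 3 to compound 4. In this assay compound 4 is expected to give about 30000 nM, most likely reported again only as a limit.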

Compound 4, half-maximal cytotoxic concentration: > 20000 nM
Compound 4: only a limit was reported; the forecaster's own chance of this, stated with the estimate: 85%; the middle value is on the limit's open side.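

No step can be read from compound 3 to compound 4, because both give only a limit and not a number in this assay: the limit of > 20000 nM in this assay, at which 4 of the 4 values shown sit.

The compounds shown leave open whether chloro and methoxy differ at either place on the shared core, and what concentration of any of these four compounds these cells would fail to tolerate.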